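Swapping a Five-Membered Ring on the Shared Core

This account rests on a few compounds, and the source may have more. Where it says the series, first, only, none or still open, it means among the compounds named here.

Of the compounds shown here, three sharing one core have been measured in an assay on isolated protein (Oryctolagus cuniculus) with Thromboxane-A synthase (Homo sapiens) as the target, tested at 1 uM; a higher number here means more inhibition at the concentration tested (going by the name of the read-out), a lower number less inhibition. Within the data shown here, compound 1 `O=c1c2ccccc2c(-c2cccnc2)nn1Cc1cccc(Cl)c1` gives 95%, and compound 2 `O=c1c2ccccc2c(-c2cccnc2)nn1CCSc1ncccn1` gives 86%; the only step between them that changes a single place, a number 9 percentage points lower from compound 1 to compound 2 (within the scatter), stays within the scatter. Compound 3 `CCn1nc(-n2ccnc2)c2ccccc2c1=O` gives 53%, the lowest of the three numbers, standing beyond the scatter below both compound 2 and compound 1.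

The next compound, compound 4 `CCn1nc(-c2cncs2)c2ccccc2c1=O`, differs from compound 3 in one place: 1,3-thiazol-5-yl in place of 1H-imidazol-1-yl on an aromatic carbon. The step from compound 1 to compound 2 changes a group on a saturated chain carbon, not the aromatic carbon touched here, so it does not bear on this change. Compound 1 and compound 2 differ from compound 3 in more than one place, so their values cannot be read as a single step either. Among the measured compounds shown here, no measured step therefore tells how this assay responds to the change.

With that in mind, the estimate for compound 4 is a change of a number 5 percentage points higher from compound 3 to compound 4 (within the scatter), which is not expected to reach beyond the scatter. Compound 4 is expected to give about 58%, in a range from 30% to 85%.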

Compound 4, a percentage reported as inhibition, at one concentration (the size of the read-out at that concentration, not a potency): 77%
Estimate against measurement, compound 4: 19 percentage points below; measured number inside the range.
By their numbers in this assay, from the lowest: compound 3; then compounds 4, 2 and 1 (each within the scatter of the next, the first and the last beyond it).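

In this assay, putting 1,3-thiazol-5-yl in place of 1H-imidazol-1-yl on this aromatic carbon gives a number 24 percentage points higher from compound 3 to compound 4 (beyond the scatter), the first step measured at this position, and it shows that the read-out responds to which five-membered ring sits there. The two groups have the same counts of heavy atoms, hydrogen-bond donors and hydrogen-bond acceptors, and both carry no net charge, so in this pair those matching counts do not keep the read-out the same; what differs in the count of atoms is that the entering ring holds a sulfur where the leaving ring holds a second nitrogen. Nothing available accounts for the rise, so this single pair records the size of the step and not the reason for it.

The compounds shown leave open how a plain phenyl ring or an amine on this aromatic carbon would compare with these two rings. They also leave open whether the step would keep its size if the ethyl group on the shared core gave way to a longer chain.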